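Swapping the furan of compound 2 for a pyridine

The source may hold more compounds than are shown below. What is called first, only, known or untested is meant among the compounds shown, and "the series" means these compounds.

Of the compounds shown here, three share a core and have been measured in a functional assay on CHO-K1 cells for antagonist activity at adenosine receptor A1 (Homo sapiens), read by a beta-galactosidase reporter and cAMP accumulation, with stated times of 15 min and 6 h; a higher number here means a weaker inhibitor, a lower number a stronger inhibitor. Compound 1 `Cc1ccc(-c2nc(N)c3ccsc3n2)o1` gives 493 nM, compound 3 `COc1ccccc1Cc1cc2c(N)nc(-c3ccc(C(F)F)o3)nc2s1` gives 516 nM, and compound 2 `Nc1nc(-c2ccc(C(F)F)o2)nc2sc(Cc3ccccc3)cc12` gives 3000 nM, the highest of the three numbers. Among the measured compounds shown here, the only single-point step seen so far, a 5.8-fold lower number from compound 2 to compound 3 (0.76 log units; beyond the scatter), concerns methoxy in place of hydrogen on an aromatic carbon. Compound 4 `Nc1nc(-c2ccncc2)nc2sc(Cc3ccccc3)cc12` differs from compound 2 by pyridin-4-yl in place of 5-(difluoromethyl)furan-2-yl on an aromatic carbon. No measured step touches this part of the molecule, so nothing shown tells the direction of this change. Compound 4 is therefore expected to stay near compound 2, with the step of a 1.3-fold higher number from compound 2 to compound 4 (0.12 log units; within the scatter) carrying wide uncertainty. The estimated value for compound 4 is 4000 nM, within 800 nM to 20000 nM.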

Compound 4, inhibition constant: 812 nM
Beside the measured number, compound 4's estimate is 4.9-fold (0.69 log units) above it, and the stated range covers the measured number.
By their numbers in this assay, from the lowest: compounds 1, 3 and 4 (each within the scatter of the next); then compound 2.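

Among the compounds shown here, this is the first measured change at the position between two ring nitrogen atoms: in this assay, pyridin-4-yl in place of 5-(difluoromethyl)furan-2-yl gives a 3.7-fold lower number from compound 2 to compound 4 (0.57 log units; beyond the scatter). The number at this position therefore responds to the group placed there, and a 5-(difluoromethyl)furan-2-yl is not needed to reach the lower number seen with compound 4. No measured evidence here explains the shift.

The compounds shown leave open whether the change of ring or the loss of the difluoromethyl group matters more. From the compounds shown here alone, how a plain furan-2-yl or a pyridin-3-yl would read at this position also remains unknown.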